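From 4-methylphenyl to 4-fluorophenyl in the series

The source may report more compounds than this note shows. Statements on the series, on what has been measured and on what is new or still open speak of the compounds shown alone.

Among the compounds with values here, compound 1 `C/C(=N\Nc1nc(-c2ccncc2)cs1)c1ccc(Cl)c(Cl)c1` gives 39800 nM in an ADME assay on J774 cells (Mus musculus) for cytotoxicity, read by resazurin assay, with a stated time of 72 h (a lower number here means that less compound is tolerated, a higher number that more compound is tolerated), as the only true number so far. Compound 2 `C/C(=N\Nc1nc(-c2ccc(C)cc2)cs1)c1ccc(Cl)c(Cl)c1` stands at > 50000 nM and this is a limit of the assay, not a number. Compound 3 `C/C(=N\Nc1nc(-c2ccc(F)cc2)cs1)c1ccc(Cl)c(Cl)c1` differs from compound 2 by fluoro in place of methyl on an aromatic carbon with fluoro in place of methyl on an aromatic carbon. Within the data shown here, the one measured step bearing on this is an at least 1.2-fold higher number from compound 1 to compound 2 (0.09 log units; that floor lies within the scatter) and it involves a different replacement. The expected step of a number no higher from compound 2 to compound 3 (the limit leaves the size open) is therefore none beyond the scatter in this assay and may again meet the limit. Compound 3 is estimated at 50000 nM with an expected range of 28000 nM to 90000 nM overall.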

Compound 3, half-maximal cytotoxic concentration: > 50000 nM
Compound 3 ended at the assay's limit; the forecaster's own chance of this, stated with the estimate: 55%; the middle value sits exactly at the limit.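

In this assay the fluoro of compound 3 sits at the limit just as the methyl of compound 2 does, so the step between these two cannot be read. Replacing the pyridin-4-yl of compound 1 with 4-fluorophenyl gives (an at least 1.2-fold higher number from compound 1 to compound 3 (0.09 log units; that floor lies within the scatter)), the same floor as 4-methylphenyl, and no order can be claimed from it. Readings at this position now crowd against one ceiling: the limit of > 50000 nM in this assay, at which 2 of the 3 values shown sit.

As far as these compounds go, how far compound 2 and compound 3 lie beyond that limit stays open. Also open, from the compounds shown here alone, is whether an amine or a carboxylic acid on this aromatic carbon would give a readable value.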